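Replacing an Ester with Benzoxazole in a Cytotoxicity Series

This account rests on a few compounds, and the source may have more. Where it says the series, first, only, none or still open, it means among the compounds named here.

Values measured in a toxicity assay on NIH3T3 cells (Mus musculus) for cytotoxicity, read by resazurin assay; on this read-out lower numbers stand for an effect already at smaller amounts and higher numbers for an effect only at larger amounts of compound:
Compound 1 `CC(=O)c1ccc(NCc2cncn2Cc2ccc(-c3ccccc3)cc2)cc1-c1ccccc1` gives > 10000 nM as a limit
Compound 2 `CCC(=O)c1ccc(NCc2cncn2Cc2ccc(-c3ccccc3)cc2)cc1-c1ccccc1` gives > 10000 nM as a limit
Compound 3 `COC(=O)c1ccc(NCc2cncn2Cc2ccc(-c3ccccc3)cc2)cc1-c1ccccc1` gives > 1000 nM as a limit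

Compound 3 stands at > 1000 nM as a limit and not as a number. Compound 4 `c1ccc(-c2ccc(Cn3cncc3CNc3ccc(-c4nc5ccccc5o4)c(-c4ccccc4)c3)cc2)cc1` differs from compound 3 by 1,3-benzoxazol-2-yl in place of methoxycarbonyl on an aromatic carbon and so carries 1,3-benzoxazol-2-yl in place of methoxycarbonyl on an aromatic carbon. Going by the values given here, two measured steps bear on this methoxycarbonyl group, namely a step that the two limits leave unreadable from compound 1 to compound 3 together with a step that the two limits leave unreadable from compound 2 to compound 3 and neither has a size to carry over. No step beyond the scatter and no direction is therefore expected in this assay and the expected change is a step that the limit leaves unreadable from compound 3 to compound 4 as an estimate only. Compound 4 is estimated at 8000 nM with an expected range of 2000 nM to 20000 nM.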

Compound 4, half-maximal effective concentration: > 10000 nM
Compound 4: a limit, no number (the forecaster's own chance of this, stated with the estimate: 65%); at least 1.2-fold (0.09 log units) between middle value and limit.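

In this assay compound 4 gives > 10000 nM, a limit and not a number, and its steps from compound 1, compound 2 and compound 3 cannot be read. The compounds shown leave open at what concentration any of the four reaches its half-maximal effect.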